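The source may hold more compounds than are shown below. What is called first, only, known or untested is meant among the compounds shown, and "the series" means these compounds.

Compound 1 `Cc1nnc(SCc2cc(=O)c3ccccc3o2)o1` carries the shared core with a 5-methyl-1,3,4-oxadiazol-2-yl on a sulfur. In a functional assay on HeLa cells (Homo sapiens) for cytotoxicity, read by MTT assay, with a stated time of 72 h (on this read-out lower numbers stand for stronger inhibition and higher numbers for weaker inhibition), compound 1 gives > 25000 nM, which is a limit of the assay and not a number. Compound 2 `Nc1nnc(SCc2cc(=O)c3ccccc3o2)s1` has 5-amino-1,3,4-thiadiazol-2-yl in place of 5-methyl-1,3,4-oxadiazol-2-yl on the sulfur. In this assay compound 2 gives > 25000 nM, again only a limit of the assay. The step that the two limits leave unreadable from compound 1 to compound 2 is therefore unreadable, because both values sit at the limit of > 25000 nM in this assay, at which 2 of the 2 values shown sit. Compound 3 `Cc1ccc2oc(CSc3nnc(C)o3)cc(=O)c2c1` keeps the group on the sulfur of compound 1 and differs by methyl in place of hydrogen on an aromatic carbon. No measured step concerns a change on that six-membered ring; the only step shown, a step that the two limits leave unreadable from compound 1 to compound 2, concerns the group on the sulfur and yields no size at all. With compound 1 itself inactive to the limit, the step expected in this assay is one of no readable size, a step that the limit leaves unreadable from compound 1 to compound 3, and the outcome is expected most likely to be reported again only as a limit. Compound 3 is thus estimated at 30000 nM, within 10000 nM to 100000 nM.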

Compound 3, half-maximal inhibitory concentration: > 25000 nM
Compound 3 gave a limit, no number (the forecaster's own chance of this, stated with the estimate: 85%); the middle value is on the limit's open side.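

In this assay compound 3 gives > 25000 nM, a limit of the assay and not a number. No size can be read for the change from compound 1 to compound 3: the limit of > 25000 nM in this assay, at which 3 of the 3 values shown sit.

The compounds shown leave open whether methyl in place of hydrogen on an aromatic carbon, or a change of the group on the sulfur, alters the read-out in this assay at all.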